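Hydroxymethyl on the Piperidine of Compound 3

The source may report more compounds than this note shows. Statements on the series, on what has been measured and on what is new or still open speak of the compounds shown alone.

Measured in a functional assay on PC-3 cells (Homo sapiens) for antiproliferative activity, read by MTT assay, with a stated time of 72 h; a lower number here means a stronger inhibitor, a higher number a weaker inhibitor:
compound 1, `COc1cc2ncnc(N3CCCc4ccccc43)c2cc1NC(=O)/C=C/CN(C)C`, gives 1750 nM
compound 2, `CCN(CC)C/C=C/C(=O)Nc1cc2c(N3CCCc4ccccc43)ncnc2cc1OC`, gives 6890 nM
compound 3, `COc1cc2ncnc(N3CCCc4ccccc43)c2cc1NC(=O)/C=C/CN1CCCCC1`, gives 5780 nM

Among the three measured compounds, compound 3 has the second highest number in this assay. Its nearest neighbour is compound 2: the step of a 1.2-fold lower number from compound 2 to compound 3 (0.08 log units; within the scatter) lies within the scatter. Compound 1 sits apart from both: the steps of a 3.9-fold higher number from compound 1 to compound 2 (0.60 log units; beyond the scatter) and a 3.3-fold higher number from compound 1 to compound 3 (0.52 log units; beyond the scatter) are beyond the scatter.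

Compound 4, `COc1cc2ncnc(N3CCCc4ccccc43)c2cc1NC(=O)/C=C/CN1CCC(CO)CC1`, differs from compound 3 by hydroxymethyl in place of hydrogen on a saturated ring carbon. None of the three measured steps bears directly on this change: each of them exchanges the whole amine on the saturated chain carbon, and none adds a group to a ring carbon of an amine that is otherwise kept. Within the data shown here, the data therefore give no precedent for the hydroxymethyl itself, only the observation that the three amines so far span a modest range. With nothing to point in either direction, compound 4 is expected to stay close to compound 3, with a step of a 1.1-fold lower number from compound 3 to compound 4 (0.02 log units; within the scatter) that is not expected to exceed the scatter. The estimate for compound 4 in this assay is 5500 nM, with a range from 2000 nM to 15000 nM.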

Compound 4, half-maximal inhibitory concentration: 7150 nM
Compound 4: the middle estimate sits 1.3-fold (0.11 log units) below what was measured; low and high end bracket the measured number.
By their numbers in this assay, from the lowest: compound 1; then compounds 3, 2 and 4 (each within the scatter of the next).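

In this assay, hydroxymethyl in place of hydrogen on this saturated ring carbon, three ring bonds from the ring nitrogen, leaves the number within the scatter (a 1.2-fold higher number from compound 3 to compound 4 (0.09 log units; within the scatter)), so this position accepts this addition with no change that can be told from the scatter. The 4-(hydroxymethyl)piperidin-1-yl amine also stays level with diethylamino (a 1.0-fold higher number from compound 2 to compound 4 (0.02 log units; within the scatter)), whereas dimethylamino remains apart from it, beyond the scatter (a 4.1-fold higher number from compound 1 to compound 4 (0.61 log units; beyond the scatter)). No available evidence offers an explanation for this result.

From the compounds shown here alone, whether a carboxylic acid, an aminomethyl or a longer chain such as hydroxyethyl on the same ring carbon would also stay within the scatter remains open. So does whether hydroxymethyl on the dimethylamino or diethylamino side chains' replacement amines, such as morpholin-4-yl, would read the same way.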